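This account rests on a few compounds, and the source may have more. Where it says the series, first, only, none or still open, it means among the compounds named here.

Measured compounds in an ADME assay on MDCK cells (Canis lupus familiaris) for cytotoxicity, read by MTT assay, with a stated time of 4 days; a higher number here means a weaker inhibitor, a lower number a stronger inhibitor:

- compound 1, `N#Cc1ccc(-c2c[nH]c(=O)c(O)c2)cc1`: > 100000 nM, a limit of the assay
- compound 2, `O=c1[nH]cc(-c2ccc(-c3nnn[nH]3)cc2)cc1O`: > 100000 nM, a limit of the assay
- compound 3, `O=c1[nH]c(-c2ccc(F)cc2)ccc1O`: > 100000 nM, a limit of the assay

Compound 3 stands at the limit of > 100000 nM in this assay, at which 3 of the 3 values shown sit; for it only a limit is known, not a number, and the two further values shown are limits too. The step under consideration leads to compound 4, `O=c1[nH]c(-c2ccc(-c3nnn[nH]3)cc2)ccc1O`, and consists of 1H-tetrazol-5-yl in place of fluoro on an aromatic carbon. Among the measured compounds shown here, the one measured step that bears on this change is a step that the two limits leave unreadable from compound 1 to compound 2, where both ends are limits and the size of the step cannot be read. For the measured compounds named here, no measured step therefore gives a direction or a size for the change from compound 3 to compound 4, and no step beyond the usual scatter is expected. Compound 4 is expected to stay at the limit of the assay, the estimated step being a step that the limit leaves unreadable from compound 3 to compound 4. The estimate for compound 4 is 150000 nM, with a range from 60000 nM to 500000 nM, and most likely the assay again reports only a limit.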

Compound 4, half-maximal inhibitory concentration: > 100000 nM
Compound 4 gave a limit, no number (the forecaster's own chance of this, stated with the estimate: 85%); the middle value is on the limit's open side.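

In this assay, compound 3 and compound 4 both give only a limit, so no step between them can be read: the limit of > 100000 nM in this assay, at which 4 of the 4 values shown sit.

The compounds shown leave open the size and direction of the change from fluoro to 1H-tetrazol-5-yl, and whether any compound in the series gives a number in this assay.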